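The source may report more compounds than this note shows. Statements on the series, on what has been measured and on what is new or still open speak of the compounds shown alone.

Measured so far: compound 1 `CC(C(=O)NCc1ccc(C(F)(F)F)nc1)c1ccc(NS(C)(=O)=O)c(F)c1`, which gives "not active" (no number reported) in a functional assay on CHO-K1 cells for antagonist activity at transient receptor potential cation channel subfamily V member 1 (Homo sapiens), read by FLIPR; a lower number here means a stronger inhibitor, a higher number a weaker inhibitor; compound 2 `Cc1ccc(Cl)cc1Nc1nc(C(F)(F)F)ccc1CNC(=O)C(C)c1ccc(NS(C)(=O)=O)c(F)c1`, which gives 140 nM in this assay; compound 3 `CCCN(CCC)c1nc(C(F)(F)F)ccc1CNC(=O)C(C)c1ccc(NS(C)(=O)=O)c(F)c1`, which gives 14.7 nM in this assay.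

Compound 3 stands lowest of the two numbers in this assay, with compound 2 nearest, while compound 1 gave no number at all. Among the compounds with values here, the only step with a number is a 9.5-fold lower number from compound 2 to compound 3 (0.98 log units; beyond the scatter). Compound 4 `CC(C(=O)NCc1ccc(C(F)(F)F)nc1N1CCCC1)c1ccc(NS(C)(=O)=O)c(F)c1` differs from compound 3 by pyrrolidin-1-yl in place of dipropylamino on an aromatic carbon. Within the data shown here, no measured step exchanges one dialkylamino group for another, so the step from compound 2 to compound 3 bears only loosely on this change; both groups keep a nitrogen on that aromatic carbon. A small move toward a higher number is expected, a 2.0-fold higher number from compound 3 to compound 4 (0.31 log units; beyond the scatter). Compound 4 is therefore expected to give 30 nM, within 8 nM to 120 nM.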

Compound 4, half-maximal inhibitory concentration: 211 nM
Estimate against measurement, compound 4: 7.0-fold (0.85 log units) below; measured number outside the range, above it.
By their numbers in this assay, from the lowest: compound 3; then compounds 2 and 4 (each within the scatter of the next).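

Keeping a nitrogen on this aromatic carbon does not by itself hold the activity in this assay: the change from dipropylamino to pyrrolidin-1-yl gives a 14-fold higher number from compound 3 to compound 4 (1.16 log units; beyond the scatter) and is the largest numbered step in the set. The other new comparison gives a 1.5-fold higher number from compound 2 to compound 4 (0.18 log units; within the scatter) for pyrrolidin-1-yl in place of (5-chloro-2-methylphenyl)amino, so these two groups cannot be told apart here. Nothing measured here accounts for the step from dipropylamino to pyrrolidin-1-yl.

The compounds shown leave open whether diethylamino would fall with dipropylamino or with pyrrolidin-1-yl. They also leave open where piperidin-1-yl would stand.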